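Benzyl hydroxamates: removing the trifluoromethyl group

The source may report more compounds than this note shows. Statements on the series, on what has been measured and on what is new or still open speak of the compounds shown alone.

Measured so far, growth inhibition of MDA-MB-231 cells, a functional assay on MDA-MB-231 cells (Homo sapiens) for antiproliferative activity; on this read-out higher numbers stand for weaker inhibition of growth and lower numbers for stronger inhibition of growth:
compound 1 `O=C(CCC1=CCN(Cc2ccc(C(F)(F)F)cc2)C1=O)NO` gives 3070 nM
compound 2 `COc1cccc(CN2CC=C(CCC(=O)NO)C2=O)c1` gives 1770 nM
compound 3 `O=C(CCC1=CCN(Cc2cccc(C(F)(F)F)c2)C1=O)NO` gives 220 nM

Compound 3 stands lowest of the three numbers in this assay, that is, it is the strongest inhibitor of growth among them. Its nearest neighbour is compound 2, and the gap to compound 1 is wider still; both gaps lie beyond the scatter.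

The next compound, compound 4 `O=C(CCC1=CCN(Cc2ccccc2)C1=O)NO`, is the plain benzyl analogue. Relative to compound 3 the change is: hydrogen in place of trifluoromethyl on an aromatic carbon.

Among the measured compounds shown here, only one measured step bears on this position of the aromatic ring, an 8.0-fold lower number from compound 2 to compound 3 (0.91 log units; beyond the scatter), where trifluoromethyl replaced methoxy. For the measured compounds named here, no measured pair shows what a bare hydrogen does at that carbon, so the direction has to be read from that single step: the trifluoromethyl group is the one feature that sets compound 3 apart from the weaker compounds 2 and 1, and taking it away is expected to cost activity. The expected step is a 4.1-fold higher number from compound 3 to compound 4 (0.61 log units; beyond the scatter), a modest loss rather than a collapse, since compound 2 with a different substituent in the same place still gives 1770 nM.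

Compound 4 is therefore estimated at 900 nM, with a range from 300 nM to 3000 nM.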

Compound 4, concentration for 50% growth inhibition: 990 nM
Estimate against measurement, compound 4: 1.1-fold (0.04 log units) below; the measured number falls inside the stated range.
By their numbers in this assay, from the lowest: compound 3; then compounds 4, 2 and 1 (each within the scatter of the next, the first and the last beyond it).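

Removing trifluoromethyl meta to a large group gives a 4.5-fold higher number from compound 3 to compound 4 (0.65 log units; beyond the scatter) in this assay, so at this carbon the group holds a gain over a bare hydrogen and not only over methoxy. Methoxy and hydrogen at this carbon cannot be told apart, with a 1.8-fold lower number from compound 2 to compound 4 (0.25 log units; within the scatter) on that exchange, so the gain seen so far belongs to trifluoromethyl and does not come from a penalty carried by methoxy. The same removal on compound 1, where trifluoromethyl stands on a different carbon of the ring, runs the other way, with a 3.1-fold lower number from compound 1 to compound 4 (0.49 log units; beyond the scatter) as its size, so among these compounds the outcome of this change depends on where the group stands.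

No measurement in hand explains these differences.

Open, on these data alone, is whether the gain is particular to trifluoromethyl or extends to other groups at this carbon, such as a chlorine atom, a nitrile or a methyl group. Also open, as far as these compounds go, is whether methoxy responds to its place on the ring as trifluoromethyl does, and whether two trifluoromethyl groups on the one ring would add to the gain or cancel it.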